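Shifting the amide nitrogen of compound 1 into a ring

The source may hold more compounds than are shown below. What is called first, only, known or untested is meant among the compounds shown, and "the series" means these compounds.

The series shares one core, shown in compound 1 `CCC(C)NC(=O)/C=C/c1c(/C=C/c2ccc(OC)cc2)cc(OC)cc1OC`, and varies only the amide end. In a functional assay on MCF7 cells (Homo sapiens) for inhibition, read by MTT assay, with a stated time of 48 h (on this read-out lower numbers stand for stronger inhibition and higher numbers for weaker inhibition), compound 1 gives 3430 nM. Compound 2 `C#CCNC(=O)/C=C/c1c(/C=C/c2ccc(OC)cc2)cc(OC)cc1OC` gives 4560 nM in this assay, and compound 3 `CCCCCN(CCCCC)C(=O)/C=C/c1c(/C=C/c2ccc(OC)cc2)cc(OC)cc1OC` gives 6130 nM. Compound 1 holds the lowest of the three numbers, yet a 1.3-fold higher number from compound 1 to compound 2 (0.12 log units; within the scatter) and a 1.8-fold higher number from compound 1 to compound 3 (0.25 log units; within the scatter) are both within the scatter, as is a 1.3-fold higher number from compound 2 to compound 3 (0.13 log units; within the scatter), so the three cannot be told apart.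

Compound 4 `COc1ccc(/C=C/c2cc(OC)cc(OC)c2/C=C/C(=O)N2CCCC(C)C2)cc1` is not yet measured. It differs from compound 1 in this way: 3-methylpiperidin-1-yl in place of (sec-butyl)amino on a carbonyl carbon. The entering group closes the nitrogen into a six-membered non-aromatic ring and removes the single hydrogen-bond donor of the leaving group. Going by the values given here, the nearest precedent is the move from a secondary amide to a tertiary one, where a 1.8-fold higher number from compound 1 to compound 3 (0.25 log units; within the scatter) stayed within the scatter, and a 1.3-fold higher number from compound 2 to compound 3 (0.13 log units; within the scatter) points the same way. Compound 4 is therefore expected to show a 1.4-fold higher number from compound 1 to compound 4 (0.15 log units; within the scatter), a step not beyond the scatter. Compound 4 is estimated at 4800 nM, with a range from 2400 nM to 9600 nM.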

Compound 4, half-maximal inhibitory concentration: 11900 nM
For compound 4 the middle estimate is 2.5-fold (0.39 log units) below the measured one, and the stated range ends below it.
By their numbers in this assay, from the lowest: compounds 1, 2, 3 and 4 (each within the scatter of the next, the first and the last beyond it).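

Going by these compounds alone, with a 3.5-fold higher number from compound 1 to compound 4 (0.54 log units; beyond the scatter) and a 2.6-fold higher number from compound 2 to compound 4 (0.42 log units; beyond the scatter) in this assay as its measure, the 3-methylpiperidin-1-yl group on the carbonyl carbon gives the first steps at this position that pass the scatter, whereas every step among compounds 1, 2 and 3 stayed within it. Yet a 1.9-fold higher number from compound 3 to compound 4 (0.29 log units; within the scatter) also stays within the scatter, so on these numbers the ring cannot be told apart from the open dipentylamino group, which likewise has no hydrogen-bond donor, and the separation holds only against the two groups that keep the amide hydrogen.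

The compounds shown leave open whether the ring or its methyl carries the step, a question that a plain piperidin-1-yl or a morpholin-4-yl group on this carbonyl carbon would address. No measurement at hand gives a reason for the step.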